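The source may report more compounds than this note shows. Statements on the series, on what has been measured and on what is new or still open speak of the compounds shown alone.

The three measured compounds, all tested in a functional assay on MCF7 cells (Homo sapiens) for cytotoxicity, read by MTT assay, with a stated time of 72 h, tested at 10 uM; a lower number here means less inhibition of growth, a higher number more inhibition of growth at the concentration tested:
Compound 1, `Cc1ccnc(/C(N)=N/NC(=S)N2CCCC2)c1`, gives 63.6%.
Compound 2, `Cc1ccnc(/C(N)=N/NC(=S)N2CCCCCC2)c1`, gives 60.3%.
Compound 3, `N/C(=N\NC(=S)N1CCN(c2ccccn2)CC1)c1ccc(F)cn1`, gives 35.8%.

Compound 3 stands lowest of these three numbers. Its nearest neighbour is compound 2, whose number lies higher by more than the usual scatter, and compound 1 lies higher still, also beyond the scatter. Compounds 1 and 2 lie within the scatter of each other, so no order can be read between them.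

Compound 4, `Cc1cccc(/C(N)=N/NC(=S)N2CCN(c3ccccn3)CC2)n1`, has not yet been measured. It differs from compound 3 in one place: 6-methylpyridin-2-yl in place of 5-fluoropyridin-2-yl on a carbon with a double bond to nitrogen. The rest of the molecule is kept. Going by the values given here, no pair of measured compounds differs in exactly this way, so the size of the step cannot be read from a matching example. Compounds 1 and 2 share part of their structure with compound 4 and give higher numbers, but they also differ from compound 4 elsewhere, so they guide only loosely. In this assay the expected step is a number 10.2 percentage points higher from compound 3 to compound 4 (beyond the scatter). Compound 4 is expected to give about 46%, with a range from 26% to 66%.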

Compound 4, percent growth inhibition at one concentration: 20.8%
The estimate for compound 4 lay 25.2 percentage points above the measured number; the measured number lies below the stated range.
By their numbers in this assay, from the lowest: compound 4; then compound 3; then compounds 2 and 1 (each within the scatter of the next).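

Going by these compounds alone, until now no measured pair differed at this place alone, so this is the first direct reading of a change on the carbon with a double bond to nitrogen: in this assay, 6-methylpyridin-2-yl in place of 5-fluoropyridin-2-yl gives a number 15 percentage points lower from compound 3 to compound 4 (beyond the scatter). The two groups match in heavy-atom count, ring type, and hydrogen-bond donor and acceptor counts, yet the number still moves beyond the scatter, so those counts alone do not settle the outcome at this position. Nothing measured here bears on why the number falls.

Still open, going by these compounds, is whether the step follows the loss of fluorine, the gain of methyl, or the place each group occupies, which a plain pyridin-2-yl or a 5-methylpyridin-2-yl could help separate. Within the data shown here, compounds 1 and 2 differ from compound 4 in more than one place, so no steps to them can be read.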